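The source may report more compounds than this note shows. Statements on the series, on what has been measured and on what is new or still open speak of the compounds shown alone.

Working notes on the coumarin-triazole series in a functional assay on MCF7 cells (Homo sapiens) for antiproliferative activity; on this read-out higher numbers stand for weaker inhibition and lower numbers for stronger inhibition.

Compound 1 `COc1ccc(-c2cn(-c3cc4ccc(O)c(C)c4oc3=O)nn2)cc1` carries a 4-methoxyphenyl on the triazole. In this assay compound 1 reaches only the limit > 100000 nM, which is a limit of the assay and not a number. Compound 2 `COc1ccc(-c2cn(-c3cc4ccc(OC(C)=O)c(C)c4oc3=O)nn2)cc1` differs by acetyl in place of hydrogen on an oxygen on an aromatic ring. In this assay compound 2 likewise returns the limit > 100000 nM, a limit and not a number. The step that the two limits leave unreadable from compound 1 to compound 2 therefore cannot be read, because the limit of > 100000 nM in this assay, at which 2 of the 3 values shown sit, hides both ends of it.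

Compound 3 `Cc1c(O)ccc2cc(-n3cc(/C=C/c4ccccc4)nn3)c(=O)oc12` changes the core by 2-phenylethenyl in place of 4-methoxyphenyl on an aromatic carbon. In this assay, among the measured compounds shown here, compound 3 gives 33700 nM, the only actual number in the set, and the step of an at least 2.9-fold lower number from compound 1 to compound 3 (0.47 log units; beyond the scatter) is the one readable change.

Compound 4 `CC(=O)Oc1ccc2cc(-n3cc(/C=C/c4ccccc4)nn3)c(=O)oc2c1C` is still to be measured. It differs from compound 3 by acetyl in place of hydrogen on an oxygen on an aromatic ring, the same change as from compound 1 to compound 2. Since that earlier step is unreadable, the expected step of a 1.2-fold higher number from compound 3 to compound 4 (0.07 log units; within the scatter) for compound 4 rests only on the number for compound 3 and an assumption of little movement. Compound 4 is estimated at 40000 nM, with a range from 15000 nM to 110000 nM.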

Compound 4, half-maximal inhibitory concentration: 28500 nM
Beside the measured number, compound 4's estimate is 1.4-fold (0.15 log units) above it, within the range that was stated.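

In this assay, acetyl in place of hydrogen on the oxygen gives a 1.2-fold lower number from compound 3 to compound 4 (0.07 log units; within the scatter), so hydroxy to acetoxy produces no change beyond the scatter on the 2-phenylethenyl core. With the acetoxy group held constant, 2-phenylethenyl in place of 4-methoxyphenyl gives an at least 3.5-fold lower number from compound 2 to compound 4 (0.54 log units; beyond the scatter), and this change points the same way on both cores, although its size cannot be compared: the same change on two cores in this assay, an at least 2.9-fold lower number (0.47 log units; beyond the scatter) from compound 1 to compound 3 and an at least 3.5-fold lower number (0.54 log units; beyond the scatter) from compound 2 to compound 4; the limit leaves it open whether they differ. This does not show the full size of that change on either core, or whether the acetyl change behaves alike on both cores, because the steps that start from or end at these limits cannot be read exactly or at all: the limit of > 100000 nM in this assay, at which 2 of the 4 values shown sit.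

The compounds shown leave open whether a longer acyl chain or a carboxylic acid on that oxygen would move the number in this assay. They also leave open what an amine on the phenyl ring of the 2-phenylethenyl group would do.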